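Methylating the Amine: From Compound 2 to Compound 4

The compounds below may be only part of what the source reports. "The series", "measured", "known", "first", "only" and "open" are said of these compounds alone.

Of the compounds shown here, three sharing one core have been measured in an assay on HEK293 cells for displacement of a labelled ligand from Melanocortin receptor 4 (Homo sapiens); a higher number here means a weaker inhibitor, a lower number a stronger inhibitor. Compound 1 `CCC(=O)N1C[C@@H](C(=O)N2CCN(c3ccc(C)cc3[C@@H](NC(=O)CCN(C)C)C(C)C)CC2)[C@H](c2ccc(Cl)cc2)C1` gives 4.6 nM, and compound 3 `CC(C)[C@H](NC(=O)CCN(C)C)c1cccc(F)c1N1CCN(C(=O)[C@@H]2CN(C(C)C)C[C@H]2c2ccc(Cl)cc2)CC1` gives 5.3 nM. Compound 2 `Cc1ccc(N2CCN(C(=O)[C@@H]3CN(C4CCOCC4)C[C@H]3c3ccc(Cl)cc3)CC2)c([C@@H](NC(=O)CN)C(C)C)c1` gives 2 nM, the lowest of the three numbers, and its gaps to compound 1 and to compound 3 both lie beyond the scatter. Compound 4 `CNCC(=O)N[C@H](c1cc(C)ccc1N1CCN(C(=O)[C@@H]2CN(C3CCOCC3)C[C@H]2c2ccc(Cl)cc2)CC1)C(C)C` has not been measured. It differs from compound 2 by a single change: methyl in place of hydrogen on an amine nitrogen. Going by the values given here, no pair of measured compounds differs by this change alone, so nothing measured here shows its effect. The added group is one carbon, and the expectation for a 1.3-fold higher number from compound 2 to compound 4 (0.10 log units; within the scatter) is a step no larger than the scatter, in either direction. Compound 4 is therefore estimated at 2.5 nM, within a range from 1 nM to 6 nM.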

Compound 4, inhibition constant: 2.1 nM
The estimate for compound 4 lay 1.2-fold (0.08 log units) above the measured number; measured number inside the range.
By their numbers in this assay, from the lowest: compounds 2 and 4 (each within the scatter of the next); then compounds 1 and 3 (each within the scatter of the next).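

In this assay, going by these compounds alone, this is the first step that isolates the change, and it reads a 1.1-fold higher number from compound 2 to compound 4 (0.02 log units; within the scatter): methyl in place of hydrogen on this amine nitrogen leaves the number within the scatter. At this position, then, going from amino to methylamino costs no measurable binding strength. No evidence is available to explain this result. Still open, as far as these compounds go, is how a larger group on the same nitrogen, such as ethyl or a longer carbon chain, would read. A second methyl on that nitrogen, giving dimethylamino on this shorter chain, is equally unsettled.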